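Methoxy on the phenyl of compound 3: expectation

A few compounds are considered here, and "the series" means these few. Any claim that something is new, unique, unknown or untested is made for them only; others in the source may bear on it.

Three dithiolane amides carrying a coumarin through a triazole linker have been run so far. Compound 1 `Cc1cc(=O)oc2cc(OCCCn3cc(CNC(=O)CCCCC4CCSS4)nn3)ccc12` gives 75.4% in a functional assay on PC-12 cells (Rattus norvegicus) for cytotoxicity, read by MTT assay, with stated times of 3 h and 2 h, tested at 50 uM (on this read-out lower numbers stand for a weaker effect and higher numbers for a stronger effect at the one concentration tested), and compound 2 `O=C(CCCCC1CCSS1)NCc1cn(CCCCOc2ccc3ccc(=O)oc3c2)nn1` gives 75.8%. Compound 3 `O=C(CCCCC1CCSS1)NCc1cn(CCCCOc2ccc3cc(-c4ccccc4)c(=O)oc3c2)nn1` gives 20.5%, the lowest of the three: its nearest neighbour is compound 1, its furthest compound 2, both beyond the scatter. Among the compounds with values here, the one step leading to it, a number 55.3 percentage points lower from compound 2 to compound 3 (beyond the scatter), is a large drop, the sole measured change in this set and the only one that bears on the next compound.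

Compound 4 `COc1ccc(-c2cc3ccc(OCCCCn4cc(CNC(=O)CCCCC5CCSS5)nn4)cc3oc2=O)cc1` differs from compound 3 by methoxy in place of hydrogen on an aromatic carbon. Within the data shown here, no measured pair shows a methoxy entering or leaving, so there is no step of the same kind to lean on; the phenyl that set compound 3 apart is kept. The expectation is therefore that compound 4 stays near compound 3, with a step of a number 1.5 percentage points higher from compound 3 to compound 4 (within the scatter) that does not clearly pass the scatter. Compound 4 is estimated at 22%, within 8% to 40%.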

Compound 4, a percentage reported as activity, at one concentration (the size of the read-out at that concentration, not a potency): 55.3%
For compound 4 the middle estimate is 33.3 percentage points below the measured one; measured number above the stated range.
By their numbers in this assay, from the lowest: compound 3; then compound 4; then compounds 1 and 2 (each within the scatter of the next).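

The phenyl on the shared core is not a fixed penalty: in this assay, adding methoxy at the far end of that phenyl, para to a large group, gives a number 34.8 percentage points higher from compound 3 to compound 4 (beyond the scatter). The low value of compound 3 therefore belongs to the plain phenyl, and it does not extend to every aryl group at this place. Even so, the 4-methoxyphenyl does not fully cancel the effect of substitution here, since replacing hydrogen with it gives a number 20.5 percentage points lower from compound 2 to compound 4 (beyond the scatter).

Nothing available here explains why methoxy has this effect.

As far as these compounds go, it remains open whether the rise is specific to methoxy or would also appear with hydroxy, fluorine or an amine at the same place on the phenyl. From the compounds shown here alone, the effect of a longer alkoxy chain such as ethoxy, or of methoxy elsewhere on that ring, also remains open.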